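Trimming the charged nitrogen substituent: from cyclohexylmethyl to isobutyl

This account rests on a few compounds, and the source may have more. Where it says the series, first, only, none or still open, it means among the compounds named here.

Measured in a functional assay (strain AB) with Danio rerio as the target, read by microscopy, with a stated time of 1 h; a higher number here means that more compound is needed for the effect, a lower number that less compound is needed:
- Compound 1 `CC(C)[N+]1(C)CCc2c(sc(NC(=O)Nc3ccc(Cl)cc3)c2C(N)=O)C1`: 960 nM
- Compound 2 `C[N+]1(CC2CCCCC2)CCc2c(sc(NC(=O)Nc3ccc(Cl)cc3)c2C(N)=O)C1`: 100 nM
- Compound 3 `CC(C)(C)OC(=O)N1CCc2c(sc(NC(=O)Nc3ccc(Cl)cc3)c2C(N)=O)C1`: > 25000 nM

The entry for compound 3 is a limit of the assay and not a number.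

Compound 2, at 100 nM, has the lower of the two numeric values, and compound 1 is its nearest neighbour. The next compound to consider is compound 4 `CC(C)C[N+]1(C)CCc2c(sc(NC(=O)Nc3ccc(Cl)cc3)c2C(N)=O)C1`. It differs from compound 2 by isopropyl in place of cyclohexyl on a saturated chain carbon bound to an amine nitrogen in a ring. In words, this is isopropyl in place of cyclohexyl on a saturated chain carbon bound to an amine nitrogen in a ring, or, cut one bond further out, cyclohexylmethyl to isobutyl.

Going by the values given here, only one measured step bears on this change: a 9.6-fold lower number from compound 1 to compound 2 (0.98 log units; beyond the scatter). That step brought in cyclohexylmethyl in place of isopropyl on an amine nitrogen in a ring. Compound 4 also gives up the cyclohexyl ring but keeps the chain carbon, so a move to a higher number in this assay is expected, probably smaller than the measured step and still beyond the scatter. The expected change is a 4.5-fold higher number from compound 2 to compound 4 (0.65 log units; beyond the scatter). One step is thin support, so the range is kept wide. Compound 4 is estimated at 450 nM, with an expected range of 150 nM to 1400 nM.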

Compound 4, half-maximal effective concentration: 380 nM
Estimate against measurement, compound 4: 1.2-fold (0.07 log units) above; the range from low to high includes it.
By their numbers in this assay, from the lowest: compound 2; then compound 4; then compound 1. At a limit, above all of these: compound 3.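

Removing the cyclohexyl ring while keeping the chain carbon gives back only part of the earlier gain: this assay shows a 3.8-fold higher number from compound 2 to compound 4 (0.58 log units; beyond the scatter), so the ring itself counts on a saturated chain carbon bound to an amine nitrogen in a ring. Isobutyl still improves on isopropyl, with a 2.5-fold lower number from compound 1 to compound 4 (0.40 log units; beyond the scatter), so the earlier single step now splits into two parts, isopropyl to isobutyl and isobutyl to cyclohexylmethyl, each beyond the scatter. Across these three compounds the number falls in the order isopropyl, isobutyl, cyclohexylmethyl, and no measured reason for either step is at hand.

Open, on these data alone, is whether cyclopentyl or phenyl in place of cyclohexyl on the chain carbon, or a longer straight carbon chain on the nitrogen, would match compound 2 at 100 nM. Compound 3 gives > 25000 nM, a limit of the assay and not a number, and it differs from the others in more than one place, so a neutral tertiary amine carrying isobutyl or cyclohexylmethyl remains the open comparison.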